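This account rests on a few compounds, and the source may have more. Where it says the series, first, only, none or still open, it means among the compounds named here.

In a functional assay on HT-29 cells (Homo sapiens) (a lower number here means a stronger inhibitor of growth, a higher number a weaker inhibitor of growth), compound 1 `O=S(=O)(/C=C/c1ccc(Br)cc1)Cc1ccc(Nc2ncnc3ccccc23)cc1` reads > 100000 nM, which is a limit of the assay. Among the compounds with values here, compound 2 `O=S(=O)(/C=C/c1ccc(Br)cc1)Cc1ccc(Nc2ncnc3ccc(Br)cc23)cc1` gives 10000 nM, the only actual number so far. Within the data shown here, the one measured step, bromo in place of hydrogen on an aromatic carbon, is an at least 10-fold lower number from compound 1 to compound 2 (1.00 log units; beyond the scatter). Compound 3 `O=S(=O)(/C=C/c1ccc(Cl)cc1Cl)Cc1ccc(Nc2ncnc3ccc(Br)cc23)cc1` changes a different place: 2,4-dichlorophenyl in place of 4-bromophenyl on a double-bonded chain carbon bound to a double-bonded chain carbon. The measured step does not touch this aryl group, so it offers no direct guide, and no shift beyond the scatter is expected in this assay. The expected change is a 1.3-fold lower number from compound 2 to compound 3 (0.10 log units; within the scatter). Compound 3 is estimated at 8000 nM, with an expected range from 2000 nM to 30000 nM.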

Compound 3, concentration for 50% growth inhibition: 28000 nM
Compound 3: middle estimate off by 3.5-fold (0.54 log units), on the low side; low and high end bracket the measured number.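

In this assay, the aryl group on the double-bonded chain carbon proves to matter: 2,4-dichlorophenyl in place of 4-bromophenyl gives a 2.8-fold higher number from compound 2 to compound 3 (0.45 log units; beyond the scatter). Within the data shown here, the earlier step changed only the shared core, so this is the first sign that this end of the molecule also affects the read-out, here for the worse. Nothing at hand accounts for the shift. The compounds shown leave open whether either chlorine alone would give the same change. They also leave open how an amine or a carboxylic acid on this phenyl ring would read.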